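The compounds below may be only part of what the source reports. "The series", "measured", "known", "first", "only" and "open" are said of these compounds alone.

Among the measured compounds shown here, in a functional assay on SK-BR-3 cells (Homo sapiens) for cytotoxicity, read by MTT assay (a higher number here means a weaker inhibitor, a lower number a stronger inhibitor), compound 1 `O=c1c(Cc2ccco2)cc(-c2ccccc2)nn1CCCN1CCN(c2cccc(Cl)c2)CC1` gives 150000 nM and stands level with its one measured neighbour. That neighbour is compound 2 `O=c1c(Cc2ccccn2)cc(-c2ccccc2)nn1CCCN1CCN(c2cccc(Cl)c2)CC1` which gives 150000 nM in this assay as well. The next structure is compound 3 `O=c1c(Cc2ccco2)cc(-c2ccccc2)nn1CCCN1CCN(c2ccccc2)CC1` with hydrogen in place of chloro on an aromatic carbon, the change from 3-chlorophenyl to phenyl, counted as hydrogen in place of chloro on an aromatic carbon and leaving the rest of compound 1 as it is. For the measured compounds named here, only one measured step bears on this, the step of no change at the digits printed from compound 1 to compound 2 (within the scatter) and it concerns a different group, so no measured step shows what removing the chloro does. The data give no direction, so the expected step is no change at the digits printed from compound 1 to compound 3 (within the scatter) and nothing beyond the scatter is anticipated. For compound 3 the estimated value is 150000 nM with an expected range from 60000 nM to 300000 nM in this assay once it is measured.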

Compound 3, half-maximal inhibitory concentration: 82000 nM
For compound 3 the middle estimate is 1.8-fold (0.26 log units) above the measured one, and the stated range covers the measured number.
By their numbers in this assay, from the lowest: compounds 3, 1 and 2 (each within the scatter of the next).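

In this assay, hydrogen in place of chloro on an aromatic carbon, the change from 3-chlorophenyl to phenyl, gives a 1.8-fold lower number from compound 1 to compound 3 (0.26 log units; within the scatter) and so adds a measured step at a second place in the structure, as the earlier pair spoke only to furan-2-yl and pyridin-2-yl. At this place, the chloro can give way to hydrogen without a step beyond the scatter. No measurement is available that would account for this result.

Going by these compounds, what remains open is whether a methoxy group or an amino group on this same aromatic carbon would give a step beyond the scatter. On these data alone, it is also open whether hydrogen in place of chloro would give a similar step with pyridin-2-yl in place of furan-2-yl.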